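This account rests on a few compounds, and the source may have more. Where it says the series, first, only, none or still open, it means among the compounds named here.

Compound 1, `Nc1ccc(S(=O)(=O)N2CCN(c3ncc(C(O)(C(F)(F)F)C(F)(F)F)cc3Br)CC2)cn1`: 32 mL.min-1.g-1
Compound 2, `Cc1csc(-c2cc(C(O)(C(F)(F)F)C(F)(F)F)cnc2N2CCN(S(=O)(=O)c3ccc(N)nc3)CC2)c1`: 399 mL.min-1.g-1

In an ADME assay (liver) for metabolic stability, with Liver microsome (Rattus norvegicus) as the target, using microsomes and NADPH, with a stated time of 30 min, tested at 1 uM (on this read-out higher numbers stand for fast clearance and lower numbers for slow clearance), compound 2 stands highest of the two measured compounds; its nearest neighbour is compound 1, and the step of a 12-fold higher number from compound 1 to compound 2 (1.10 log units; beyond the scatter) is large and well beyond the scatter.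

Compound 3, `Nc1ccc(S(=O)(=O)N2CCN(c3ncc(C(O)(C(F)(F)F)C(F)(F)F)cc3-c3ccc4ocnc4c3)CC2)cn1`, is not yet measured. It differs from compound 2 in one place: 1,3-benzoxazol-5-yl in place of 4-methylthiophen-2-yl on an aromatic carbon

Within the data shown here, only one measured step bears on this change, a 12-fold higher number from compound 1 to compound 2 (1.10 log units; beyond the scatter), which shows that putting a ring group in this place in the shared core can move the read-out a long way. Here one ring group is exchanged for another, so no step of that size is expected in either direction, but a moderate move cannot be ruled out. The estimated step of a 2.2-fold lower number from compound 2 to compound 3 (0.35 log units; beyond the scatter) for compound 3 is therefore modest and downward. Compound 3 is expected to give about 180 mL.min-1.g-1, with a range from 60 mL.min-1.g-1 to 500 mL.min-1.g-1.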

Compound 3, intrinsic clearance in microsomes: 120 mL.min-1.g-1
Estimate against measurement, compound 3: 1.5-fold (0.18 log units) above; the measured number falls inside the stated range.
By their numbers in this assay, from the lowest: compound 1; then compound 3; then compound 2.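

In this assay, swapping one ring group for another at this position on the shared core still shifts the read-out: 1,3-benzoxazol-5-yl in place of 4-methylthiophen-2-yl gives a 3.3-fold lower number from compound 2 to compound 3 (0.52 log units; beyond the scatter). Both ring groups give higher numbers than bromo, but the rise with 1,3-benzoxazol-5-yl is only a 3.8-fold higher number from compound 1 to compound 3 (0.57 log units; beyond the scatter), so the much larger rise seen with 4-methylthiophen-2-yl does not come with every ring group placed here. No measurement available here explains why the two ring groups differ.

The exchange changes the ring count and the hetero atoms together, and the compounds shown cannot separate these two differences. Going by these compounds, it also remains open where a plain phenyl ring or a saturated amine such as morpholine would fall relative to these three compounds.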